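The source may hold more compounds than are shown below. What is called first, only, known or untested is meant among the compounds shown, and "the series" means these compounds.

Measured compounds in the series:

Compound 1, `COc1nc(C(C)(C)C)ccc1[C@@H](c1ccccc1)[C@@](O)(CCN(C)C)c1cccc2ccccc12`, gives 27.6 ug/mL in a toxicity assay on Vero cells (Chlorocebus sabaeus) for cytotoxicity; on this read-out lower numbers stand for higher toxicity in this test and higher numbers for lower toxicity in this test.
Compound 2, `COc1nc(-c2ccc(F)cc2)ccc1[C@@H](c1ccccc1)[C@@](O)(CCN(C)C)c1cccc2ccccc12`, reaches only the limit of > 50 ug/mL in this assay.
Compound 3, `COc1ccc(-c2ccc([C@@H](c3ccccc3)[C@@](O)(CCN(C)C)c3cccc4ccccc34)c(OC)n2)cc1`, likewise reaches only the limit of > 50 ug/mL in this assay.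

Compound 3 thus stands at the upper limit of this assay, and no number is known for it; the same holds for (the limit of > 50 ug/mL in this assay, at which 2 of the 3 values shown sit).

Compound 4, `COc1nc(-c2cccc(F)c2)ccc1[C@@H](c1ccccc1)[C@@](O)(CCN(C)C)c1cccc2ccccc12`, differs from compound 3 in one place: 3-fluorophenyl in place of 4-methoxyphenyl on an aromatic carbon.

Bearing on this change are an at least 1.8-fold higher number from compound 1 to compound 3 (0.25 log units; that floor lies within the scatter) and a step that the two limits leave unreadable from compound 2 to compound 3. The step of an at least 1.8-fold higher number from compound 1 to compound 2 (0.25 log units; that floor lies within the scatter) shows that a fluorophenyl group at this position already runs into the limit of this assay. Nothing in the series separates the fluorophenyl compounds from the methoxyphenyl compound, since both sit at the limit.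

For compound 4 the expected value in this assay is 50 ug/mL, with a range from 25 ug/mL to 100 ug/mL, most likely reported again as a limit. The step of a number no higher from compound 3 to compound 4 (the limit leaves the size open) is expected to be none beyond the scatter.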

Compound 4, half-maximal cytotoxic concentration: > 50 ug/mL
Compound 4 gave a limit, no number; the forecaster's own chance of this, stated with the estimate: 65%; the middle value sits exactly at the limit.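

Across 4-fluorophenyl, 4-methoxyphenyl and now 3-fluorophenyl, the aryl groups at this position all end at the same limit in this assay, so a shift of the fluoro group on the ring shows no readable effect on the read-out. Against tert-butyl the series now holds an at least 1.8-fold higher number from compound 1 to compound 4 (0.25 log units; that floor lies within the scatter), the third such floor for an aryl group, and none of these floors separates an aryl compound firmly from compound 1. The steps among compound 2, compound 3 and compound 4 cannot be read, since each has a limit at both ends: the limit of > 50 ug/mL in this assay, at which 3 of the 4 values shown sit.

As far as these compounds go, how far the three aryl compounds lie past that limit, and whether they differ from one another, stays open. Also open, from the compounds shown here alone, is how an amine or a carboxylic acid on the aryl group, or a methyl group in place of it, would read in this assay.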